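The source may hold more compounds than are shown below. What is called first, only, known or untested is meant among the compounds shown, and "the series" means these compounds.

Values measured so far in a functional assay on HCT-116 cells (Homo sapiens) for antiproliferative activity, read by WST assay, with a stated time of 72 h (a lower number here means a stronger inhibitor of growth, a higher number a weaker inhibitor of growth), are these:

Compound 1 `O=C(NO)c1cnc(N2C[C@@H]3[C@H](C2)[C@H]3NC(=O)c2ccccc2)nc1` gives 5100 nM
Compound 2 `O=C(NO)c1cnc(N2C[C@@H]3[C@H](C2)[C@H]3NCc2ccccc2)nc1` gives 120 nM

Compound 2 holds the lower of the two numbers, and compound 1 lies well above it, so compound 2 is the stronger inhibitor of growth of this pair. Going by the values given here, the only measured step, a 43-fold lower number from compound 1 to compound 2 (1.63 log units; beyond the scatter), is large and comes with benzyl in place of benzoyl on an amine nitrogen.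

Compound 3 `O=C(NO)c1cnc(N2C[C@@H]3[C@H](C2)[C@H]3NCc2ccc(C(F)(F)F)cc2)nc1` keeps that benzyl form and carries trifluoromethyl in place of hydrogen on an aromatic carbon, para to a large group (trifluoromethyl in place of hydrogen on an aromatic carbon). The measured step changed a different place, so it says nothing about this change in size or direction. The best guide is therefore compound 2 itself, at 120 nM, and no step beyond the scatter is expected in this assay, with the range kept wide on both sides. The estimated change is a 1.2-fold lower number from compound 2 to compound 3 (0.08 log units; within the scatter), which is expected to stay within the scatter. For compound 3 the expected value is 100 nM, with an estimated range from 35 nM to 300 nM.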

Compound 3, concentration for 50% growth inhibition: 700 nM
Estimate against measurement, compound 3: 7.0-fold (0.85 log units) below, and the stated range ends below it.
By their numbers in this assay, from the lowest: compound 2; then compound 3; then compound 1.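

In this assay, the ring of the benzyl group proves not to be a neutral place for substitution: with trifluoromethyl in place of hydrogen on an aromatic carbon, para to a large group, the data show a 5.8-fold higher number from compound 2 to compound 3 (0.77 log units; beyond the scatter), so this compound is the weaker inhibitor of growth of the pair. The earlier step showed only what a change on the amine nitrogen does, whereas this one shows that the number also responds to a change on the aromatic ring while the benzyl form and the shared core stay as they were. Nothing measured here gives a reason for this step, which therefore stands as an observation without an explanation.

This single substituent cannot show whether the higher number belongs to trifluoromethyl in particular or to any replacement of that hydrogen. The compounds shown leave open how a fluorine atom, a methoxy group, a nitrile or a carboxylic acid at this same place would read, and whether any of them would match or better compound 2, which gives 120 nM.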